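The source may report more compounds than this note shows. Statements on the series, on what has been measured and on what is new or still open speak of the compounds shown alone.

Of the compounds shown here, three sharing one core have been measured in a functional assay on MDA-MB-231 cells (Homo sapiens) for inhibition, read by MTT assay, with a stated time of 72 h; on this read-out higher numbers stand for weaker inhibition and lower numbers for stronger inhibition. Compound 1 `O=C(CSc1nc(Nc2ccccc2)c2ccccc2n1)Nc1ccccc1F` carries a 2-fluorophenyl on an amide-type nitrogen; in this assay compound 1 gives only a limit of > 50000 nM, which is the limit of > 50000 nM in this assay, at which 1 of the 3 values shown sits. Compound 2 `O=C(CSc1nc(Nc2ccccc2)c2ccccc2n1)Nc1cccc([N+](=O)[O-])c1`, with 3-nitrophenyl in that place, gives 33000 nM, and compound 3 `COc1cccc(NC(=O)CSc2nc(Nc3ccccc3)c3ccccc3n2)c1`, with 3-methoxyphenyl, gives 21700 nM. Compound 3 therefore holds the lowest of the two actual numbers, though its gap to compound 2, a 1.5-fold lower number from compound 2 to compound 3 (0.18 log units; within the scatter), sits within the scatter; the step of an at least 1.5-fold lower number from compound 1 to compound 2 (0.18 log units; that floor lies within the scatter) is likewise small, while an at least 2.3-fold lower number from compound 1 to compound 3 (0.36 log units; beyond the scatter) is at least modest.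

Compound 4 `O=C(CSc1nc(Nc2ccccc2)c2ccccc2n1)Nc1ccc(Cl)cc1` differs from compound 3 by 4-chlorophenyl in place of 3-methoxyphenyl on an amide-type nitrogen. For the measured compounds named here, no measured step involves a 4-chlorophenyl, and the only steps at hand swap one substituted phenyl for another on the same nitrogen with effects that are small or uncertain. He therefore expects no step beyond the scatter, a 1.2-fold higher number from compound 3 to compound 4 (0.06 log units; within the scatter), and estimates that compound 4 gives about 25000 nM in this assay, between 9000 nM and 60000 nM.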

Compound 4, half-maximal inhibitory concentration: 17200 nM
Compound 4: middle estimate off by 1.5-fold (0.16 log units), on the high side, and the stated range covers the measured number.
By their numbers in this assay, from the lowest: compounds 4, 3 and 2 (each within the scatter of the next). At a limit, above all of these: compound 1.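

In this assay, 4-chlorophenyl on the amide-type nitrogen gives no separable change against the groups it is compared with here, with a 1.3-fold lower number from compound 3 to compound 4 (0.10 log units; within the scatter) and a 1.9-fold lower number from compound 2 to compound 4 (0.28 log units; within the scatter). Only against the 2-fluorophenyl does it stand apart, with an at least 2.9-fold lower number from compound 1 to compound 4 (0.46 log units; beyond the scatter), so compound 4 joins compound 3 as a second compound separated from compound 1 beyond the scatter. Compound 1 remains the only compound at a limit: the limit of > 50000 nM in this assay, at which 1 of the 4 values shown sits.

The compounds shown leave open whether an amine or a carboxylic acid on this phenyl, or a longer chain in its place, would move the number beyond the scatter of compound 2, compound 3 and compound 4. As far as these compounds go, it also stays open whether the chlorine itself or its place on the ring matters for the reading of compound 4.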